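The source may report more compounds than this note shows. Statements on the series, on what has been measured and on what is new or still open speak of the compounds shown alone.

Measured compounds:
compound 1 `Cc1ccc(CNC(=O)c2[nH]c3ccc(Cl)cc3c2S(=O)(=O)c2cc(C)cc(C)c2)cc1` — 21200 nM
compound 2 `Cc1cc(C)cc(S(=O)(=O)c2c(C(=O)NCc3ccc([N+](=O)[O-])cc3)[nH]c3ccc(Cl)cc23)c1` — a limit only, > 50200 nM
compound 3 `Cc1cc(C)cc(S(=O)(=O)c2c(C(=O)NCc3ccc(N)cc3)[nH]c3ccc(Cl)cc23)c1` — 6370 nM

In an ADME assay on MT4 cells (Homo sapiens) for cytotoxicity, read by MTT assay (a higher number here means that more compound is tolerated, a lower number that less compound is tolerated), compound 1 gives 21200 nM and holds the highest of the two numbers; the nearest number belongs to compound 3, a 3.3-fold lower number from compound 1 to compound 3 (0.52 log units; beyond the scatter). Compound 2 sits at the limit of > 50200 nM in this assay, at which 1 of the 3 values shown sits. Compound 2 therefore stands apart from compound 1 only as an at least 2.3-fold higher number from compound 1 to compound 2 (0.37 log units; beyond the scatter), a step whose full size is not known.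

Compound 4 `Cc1cc(C)cc(S(=O)(=O)c2c(C(=O)NCc3ccc(N(C)C)cc3)[nH]c3ccc(Cl)cc23)c1` differs from compound 1 in one place: dimethylamino in place of methyl on an aromatic carbon.

Among the measured compounds shown here, two measured steps bear on this change, both at the same aromatic carbon. The amino step, a 3.3-fold lower number from compound 1 to compound 3 (0.52 log units; beyond the scatter), pulled the number down; the nitro step, an at least 2.3-fold higher number from compound 1 to compound 2 (0.37 log units; beyond the scatter), pushed it up to the limit. Dimethylamino is a nitrogen substituent like amino rather than like nitro, so the amino step is the closer guide. A downward step of roughly the same size as the amino step is expected, though without a measured dimethylamino pair the size remains uncertain and a step hidden within the scatter cannot be excluded.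

For compound 4 the expected step is a 2.4-fold lower number from compound 1 to compound 4 (0.37 log units; beyond the scatter). The estimate for compound 4 in this assay is 9000 nM, within the range 3500 nM to 25000 nM.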

Compound 4, half-maximal cytotoxic concentration: 40700 nM
The estimate for compound 4 lay 4.5-fold (0.66 log units) below the measured number, outside the stated range (above it).
By their numbers in this assay, from the lowest: compound 3; then compounds 1 and 4 (each within the scatter of the next). At a limit, above all of these: compound 2.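

In this assay, a nitrogen substituent at this aromatic carbon does not by itself bring the number down: the two methyl groups on that nitrogen separate compound 4 from the amino compound (a 6.4-fold higher number from compound 3 to compound 4 (0.81 log units; beyond the scatter)). Against methyl, the change stays within the scatter (a 1.9-fold higher number from compound 1 to compound 4 (0.28 log units; within the scatter)), so among compounds 1, 3 and 4 only the amino group stands apart, and compounds 1 and 4 cannot be put in order. Compound 2 is a limit, and its step to compound 4 has only a floor (an at least 1.2-fold lower number from compound 2 to compound 4 (0.09 log units; that floor lies within the scatter)), so how far the two lie apart cannot be read: the limit of > 50200 nM in this assay, at which 1 of the 4 values shown sits.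

The compounds shown leave open whether a single methyl on the nitrogen, as in methylamino, is enough to lift the number away from that of compound 3, and whether diethylamino or morpholine would track dimethylamino. They also leave open where an acetamido group or a carboxylic acid at this carbon would fall, and whether the amino step holds on a different core.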